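Removing the Fluorine from Compound 1: an Expectation

A few compounds are considered here, and "the series" means these few. Any claim that something is new, unique, unknown or untested is made for them only; others in the source may bear on it.

Compound 1 `NS(=O)(=O)c1ccc(Nc2ncc(F)c(Nc3nc4ccccc4s3)n2)cc1`: 3260 nM
Compound 2 `Cc1cnc(Nc2ccc(Cl)cc2)nc1Nc1nc2ccccc2s1`: a limit, > 50000 nM
Compound 3 `Cc1cnc(Nc2ccc([N+](=O)[O-])cc2)nc1Nc1nc2ccccc2s1`: 6330 nM

In a functional assay on HCT-116 cells (Homo sapiens) for antiproliferative activity, read by MTT assay, with a stated time of 48 h (a higher number here means a weaker inhibitor, a lower number a stronger inhibitor), compound 1 gives 3260 nM. Compound 3 lies within the scatter of compound 1, so the two cannot be ranked. Compound 2 gives only a limit in this assay (the limit of > 50000 nM in this assay, at which 1 of the 3 values shown sits). Among the measured compounds shown here, the one measured step, an at least 7.8-fold lower number from compound 2 to compound 3 (0.89 log units; beyond the scatter), concerns the group on the aniline and says nothing about the position altered here.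

Compound 4 `NS(=O)(=O)c1ccc(Nc2nccc(Nc3nc4ccccc4s3)n2)cc1` differs from compound 1 as follows: hydrogen in place of fluoro on an aromatic carbon. For the measured compounds named here, no measured pair shows this change, so the expectation rests on compound 1 alone. A step within the scatter is expected, a 1.5-fold higher number from compound 1 to compound 4 (0.19 log units; within the scatter), perhaps leaning toward a weaker inhibitor. Compound 4 is therefore estimated at 5000 nM, with a range from 1500 nM to 16000 nM in this assay.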

Compound 4, half-maximal inhibitory concentration: 5170 nM
Beside the measured number, compound 4's estimate is 1.0-fold (0.01 log units) below it, within the range that was stated.
By their numbers in this assay, from the lowest: compounds 1, 4 and 3 (each within the scatter of the next). At a limit, above all of these: compound 2.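

In this assay, among the compounds shown here, the swap gives a 1.6-fold higher number from compound 1 to compound 4 (0.20 log units; within the scatter), the first direct reading of this change at this position, which the earlier compounds could not supply. Compound 1 and compound 4 cannot be ranked, so with this aniline the fluoro on the aromatic carbon is not shown to matter in this assay. Nothing measured here bears on why the two compounds agree.

On these data alone, whether a nitrile or an amine at this position would give a step beyond the scatter remains open. So does whether hydrogen in place of fluoro gives the same result with a different group on the aniline.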